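The source may hold more compounds than are shown below. What is called first, only, known or untested is meant among the compounds shown, and "the series" means these compounds.

Measured in a functional assay on K562 cells (Homo sapiens) for cytotoxicity, read by MTT assay, with a stated time of 24 h; on this read-out higher numbers stand for weaker inhibition and lower numbers for stronger inhibition:
- compound 1 `COc1cc(/C=C2\CN(C)C/C(=C\c3ccc(F)cc3)C2=O)cc(OC)c1`: 11300 nM
- compound 2 `COc1cc(/C=C2\CN(C)C/C(=C\c3ccc(Cl)cc3)C2=O)cc(OC)c1`: 13300 nM
- compound 3 `COc1cc(/C=C2\CN(C)C/C(=C\c3ccc(Cl)cc3Cl)C2=O)cc(OC)c1`: 11900 nM

The three values lie within the scatter of one another, so compound 3, at 11900 nM, holds no distinct rank in this small set.

Next in the series is compound 4 `COc1cc(/C=C2\CN(C)C/C(=C\c3ccc(Cl)c(Cl)c3)C2=O)cc(OC)c1`, which differs from compound 3 as follows: 3,4-dichlorophenyl in place of 2,4-dichlorophenyl on a double-bonded chain carbon bound to a double-bonded ring carbon. This places 3,4-dichlorophenyl in place of 2,4-dichlorophenyl on a double-bonded chain carbon bound to a double-bonded ring carbon, and the two compounds have the same atoms, joined differently.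

Going by the values given here, three measured steps bear on this change. Chloro in place of fluoro gave a 1.2-fold higher number from compound 1 to compound 2 (0.07 log units; within the scatter). Chloro in place of hydrogen gave a 1.1-fold lower number from compound 2 to compound 3 (0.05 log units; within the scatter). The exchange of 4-fluorophenyl for 2,4-dichlorophenyl gave a 1.1-fold higher number from compound 1 to compound 3 (0.02 log units; within the scatter). Among the compounds with values here, all three are small, but none of them moves a chlorine from one place on the ring to another, so the data hold no direct precedent for this change. With no measured step beyond the scatter, no shift beyond the scatter is expected in this assay, and no direction is favoured.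

The expected change is a 1.0-fold lower number from compound 3 to compound 4 (0.01 log units; within the scatter).

For compound 4 the estimate is 11500 nM, with an expected range of 6000 nM to 22000 nM.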

Compound 4, half-maximal inhibitory concentration: 9490 nM
Estimate against measurement, compound 4: 1.2-fold (0.08 log units) above; low and high end bracket the measured number.
By their numbers in this assay, from the lowest: compounds 4, 1, 3 and 2 (each within the scatter of the next).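

In this assay, going by these compounds alone, the exchange of 2,4-dichlorophenyl for 3,4-dichlorophenyl on a double-bonded chain carbon bound to a double-bonded ring carbon gives a 1.3-fold lower number from compound 3 to compound 4 (0.10 log units; within the scatter), the first direct reading of the same two chlorines joined differently on this aromatic ring, and the two arrangements are not separated here. Chloro in place of hydrogen on an aromatic carbon, now read in the 3,4-dichlorophenyl arrangement, gives a 1.4-fold lower number from compound 2 to compound 4 (0.15 log units; within the scatter), and 3,4-dichlorophenyl in place of 4-fluorophenyl gives a 1.2-fold lower number from compound 1 to compound 4 (0.08 log units; within the scatter), so all four compounds remain within the scatter across each change of halogen, halogen count and arrangement shown at this place. No supporting measurement is available to account for any of these small steps.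

Still open, on these data alone, is whether this place tolerates groups other than fluoro and chloro on the aromatic ring, such as a nitrophenyl, an aminophenyl or a carboxyphenyl group in place of the dichlorophenyl groups. Also open, as far as these compounds go, is whether the close grouping of these four compounds extends to any read-out other than this assay as reported here.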